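Shortening the chain on the shared core of compound 3

A few compounds are considered here, and "the series" means these few. Any claim that something is new, unique, unknown or untested is made for them only; others in the source may bear on it.

Compound 3 `CCCCCCCc1ccc(NC(=O)N[C@H](C)c2ccccc2)cc1` gives 100% in an ADME assay on the whole organism with Oryza sativa as the target, tested at 10 uM (on this read-out lower numbers stand for a stronger effect and higher numbers for a weaker effect at the one concentration tested), the highest of the three numbers measured. Compound 1 `CCc1ccc(NC(=O)N[C@H](C)c2ccccc2)cc1` gives 44% and compound 2 `CCCc1ccc(NC(=O)N[C@H](C)c2ccccc2)cc1` gives 35% in this assay, and the step of a number 9 percentage points lower from compound 1 to compound 2 (within the scatter). The steps of a number 56 percentage points higher from compound 1 to compound 3 (beyond the scatter) and a number 65 percentage points higher from compound 2 to compound 3 (beyond the scatter) both show a far longer chain on the shared core going with a much higher number. Compound 4 `CC(=O)c1ccc(NC(=O)N[C@H](C)c2ccccc2)cc1` differs from compound 3 by acetyl in place of heptyl on an aromatic carbon. Within the data shown here, compound 4 thus carries a group with far fewer chain carbons, like compounds 1 and 2, so the two large steps toward compound 3 are expected to run roughly backwards, though no measured compound here carries an oxygen in that group. Compound 4 is therefore expected to give 45%, between 15% and 80%. This means an expected step of a number 55 percentage points lower from compound 3 to compound 4 (beyond the scatter).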

Compound 4, a percentage reported as activity, at one concentration (the size of the read-out at that concentration, not a potency): 84%
Compound 4: the middle estimate sits 39 percentage points below what was measured, and the stated range ends below it.
By their numbers in this assay, from the lowest: compounds 2 and 1 (each within the scatter of the next); then compound 4; then compound 3.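

At this aromatic carbon, a short group does not by itself give a low number in this assay: acetyl stands well above the short alkyl chains, with a number 40 percentage points higher from compound 1 to compound 4 (beyond the scatter) and a number 49 percentage points higher from compound 2 to compound 4 (beyond the scatter). Acetyl in place of heptyl brings only a modest change, a number 16 percentage points lower from compound 3 to compound 4 (beyond the scatter), so chain length alone does not set the number here. No available evidence explains the difference between acetyl and the alkyl chains. The compounds shown leave open whether the carbonyl is what matters, and how an amine or a carboxylic acid on this carbon would compare.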